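A few compounds are considered here, and "the series" means these few. Any claim that something is new, unique, unknown or untested is made for them only; others in the source may bear on it.

Compound 1 `Nc1cc(N)c2nc(-c3ccccc3)c(Oc3ccc(Cl)c(Cl)c3)nc2c1` is read in a functional assay on SF-268 cells (Homo sapiens) for inhibition, read by sulforhodamine B assay, with a stated time of 48 h (a lower number here means that less compound is tolerated, a higher number that more compound is tolerated), only as a limit, < 100000 nM. Compound 2 `Nc1cc(N)c2nc(-c3ccccc3)c(Sc3ccc(Cl)c(Cl)c3)nc2c1` likewise gives only a limit in this assay, < 100000 nM. The step that the two limits leave unreadable from compound 1 to compound 2 therefore cannot be sized; the one thing in hand is the limit of < 100000 nM in this assay, at which 2 of the 2 values shown sit. Compound 3 `Nc1cc(N)c2nc(-c3ccccc3)c(Oc3ccc(F)cc3)nc2c1` differs from compound 2 by 4-fluorophenoxy in place of (3,4-dichlorophenyl)sulfanyl on an aromatic carbon. With no readable step, the expectation for compound 3 in this assay rests on both measured compounds sitting under the same limit: a step that the limit leaves unreadable from compound 2 to compound 3 of no clear size is expected, and compound 3 is estimated at 20000 nM, within 3000 nM to 90000 nM.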

Compound 3, concentration lethal to 50% of the cells: < 100000 nM
Compound 3 ended at the assay's limit; the forecaster's own chance of this, stated with the estimate: 50%; the middle value does not contradict the limit.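

No step between compound 1, compound 2 and compound 3 can be read in this assay, as all three values are limits: the limit of < 100000 nM in this assay, at which 3 of the 3 values shown sit.

The compounds shown leave open whether 3,4-dichlorophenoxy, (3,4-dichlorophenyl)sulfanyl and 4-fluorophenoxy differ at all on the shared core.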